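Iodo in place of bromo on a shared core

The source may report more compounds than this note shows. Statements on the series, on what has been measured and on what is new or still open speak of the compounds shown alone.

Compound 1 `C=C1C(n2cc(Cl)c(N)nc2=O)O[C@H](CO)[C@@H]1O` and compound 2 `C=C1C(n2cc(Br)c(N)nc2=O)O[C@H](CO)[C@@H]1O` share one core and differ only in the halogen on the aromatic carbon. In a functional assay on L1210 cells (Mus musculus) for cytotoxicity (a higher number here means a weaker inhibitor, a lower number a stronger inhibitor), compound 1 gives > 100 ug/mL, which is a limit of the assay and not a number. In this assay compound 2 likewise gives > 100 ug/mL, again a limit of the assay. The change of bromo in place of chloro, a step that the two limits leave unreadable from compound 1 to compound 2, therefore cannot be read in size. Compound 2 thus stands only at a limit, and the limit of > 100 ug/mL in this assay, at which 2 of the 2 values shown sit, shows that both measured values sit there.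

Compound 3 `C=C1C(n2cc(I)c(N)nc2=O)O[C@H](CO)[C@@H]1O` follows by iodo in place of bromo on an aromatic carbon. For the measured compounds named here, the single measured step bears on it only as an unreadable change between two limits, so no direction can be taken from it. Since compound 1 and compound 2 both reached only the limit, the expectation for compound 3 is that this assay again reports a limit rather than a number. The expected step of a number no higher from compound 2 to compound 3 (the limit leaves the size open) is none beyond the scatter. Compound 3 is estimated at 100 ug/mL, within 40 ug/mL to 300 ug/mL, with a limit the most likely outcome.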

Compound 3, half-maximal inhibitory concentration: > 100 ug/mL
Compound 3: a limit, no number; the forecaster's own chance of this, stated with the estimate: 80%; the middle value lies on the limit itself.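

In this assay compound 3 gives > 100 ug/mL, a limit of the assay and not a number. No step from compound 1 or compound 2 to compound 3 can therefore be read: the limit of > 100 ug/mL in this assay, at which 3 of the 3 values shown sit.

The compounds shown leave open whether the choice of halogen on the aromatic carbon changes the result in this assay at all.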